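From compound 2 to compound 3: fluoro for methyl

A few compounds are considered here, and "the series" means these few. Any claim that something is new, unique, unknown or untested is made for them only; others in the source may bear on it.

In a functional assay on MDA-MB-453 cells (Homo sapiens) for cytotoxicity, read by MTT assay, with a stated time of 48 h (on this read-out higher numbers stand for weaker inhibition and lower numbers for stronger inhibition), compound 1 (`N#Cc1ccc(OCc2nnc(-c3ccccc3)o2)cc1F`) gives > 50000 nM as a limit. Compound 2 (`Cc1ccc(-c2nnc(COc3ccc(C#N)c(F)c3)o2)cc1`) gives > 50000 nM as a limit too and so has no number of its own. Going by the values given here, the only measured step is a step that the two limits leave unreadable from compound 1 to compound 2 and offers no size to carry over. Measured so far is the limit of > 50000 nM in this assay, at which 2 of the 2 values shown sit, and nothing firmer. Compound 3 (`N#Cc1ccc(OCc2nnc(-c3ccc(F)cc3)o2)cc1F`) differs from compound 2 by fluoro in place of methyl on an aromatic carbon as fluoro in place of methyl on an aromatic carbon. In this assay the expected step is a number no higher from compound 2 to compound 3 (the limit leaves the size open) with no shift beyond the scatter in either direction. Compound 3 is estimated at 50000 nM with a range from 25000 nM to 100000 nM and is expected to be reported only as a limit.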

Compound 3, half-maximal inhibitory concentration: 25100 nM
Beside the measured number, compound 3's estimate is 2.0-fold (0.30 log units) above it, within the range that was stated.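

Going by these compounds alone, compound 3, with 4-fluorophenyl, is the first compound here to give a number, while the others stay at a limit: the limit of > 50000 nM in this assay, at which 2 of the 3 values shown sit.
At this place, para to a large group, the change to fluoro gives an at least 1.9-fold lower number from compound 2 to compound 3 (0.29 log units; that floor lies within the scatter) from methyl and an at least 1.9-fold lower number from compound 1 to compound 3 (0.29 log units; that floor lies within the scatter) from hydrogen. Both are floors within the scatter, so they fix no size for either change, and the step from hydrogen to methyl cannot be read.
Going by these compounds, whether fluoro differs from chloro or methoxy at this place stays open, as does how an amine there would read.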